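A few compounds are considered here, and "the series" means these few. Any claim that something is new, unique, unknown or untested is made for them only; others in the source may bear on it.

Measured in a functional assay (aorta) with Oryctolagus cuniculus as the target; a higher number here means a weaker inhibitor, a lower number a stronger inhibitor:
- compound 1 `CC1=NC(C)=C(C(=O)OCCCN2C(=O)c3ccccc3S2(=O)=O)C(c2cccc(Cl)c2Cl)/C1=C(\O)OCC1CCCCO1` gives 4 nM
- compound 2 `CCO/C(O)=C1\C(C)=NC(C)=C(C(=O)OCCCN2C(=O)c3ccccc3S2(=O)=O)C1c1ccccc1C(F)(F)F` gives 0.8 nM
- compound 3 `COCCO/C(O)=C1\C(C)=NC(C)=C(C(=O)OCCCN2C(=O)c3ccccc3S2(=O)=O)C1c1ccccc1C(F)(F)F` gives 1.4 nM

Among these, compound 3 (1.4 nM) lies within the scatter of compound 2, and its number is lower than that of compound 1 by more than the scatter.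

Going by the values given here, the next structure is compound 4 `CC1=NC(C)=C(C(=O)OCCCN2C(=O)c3ccccc3S2(=O)=O)C(c2ccccc2C(F)(F)F)/C1=C(\O)OCC1CCCCO1`, which has no measurement yet. It differs from compound 3 by having oxan-2-yl in place of methoxymethyl on a saturated chain carbon bound to an oxygen on an unsaturated carbon and is otherwise the same.

Among the compounds with values here, only one measured step changes this part of the structure, the one that puts methoxy in place of hydrogen (a 1.8-fold higher number from compound 2 to compound 3 (0.24 log units; within the scatter)). That step stayed within the scatter. Compound 1 also has oxan-2-yl in this place and gives 4 nM but differs from compound 4 elsewhere, so it offers a hint and not a direct step. Taken together, these data lead to an expectation of no step beyond the scatter in this assay, with a slight lean toward a higher number. The expected change is a 1.4-fold higher number from compound 3 to compound 4 (0.15 log units; within the scatter) (an estimate, not a measurement). For compound 4 the estimated value is 2 nM and the expected range runs from 0.7 nM up to 6 nM in this estimate.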

Compound 4, half-maximal inhibitory concentration: 1.4 nM
For compound 4 the middle estimate is 1.4-fold (0.15 log units) above the measured one, and the stated range covers the measured number.
By their numbers in this assay, from the lowest: compounds 2, 3 and 4 (each within the scatter of the next); then compound 1.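

In this assay the step that puts oxan-2-yl in place of methoxymethyl, on a saturated chain carbon bound to an oxygen on an unsaturated carbon, gives no change at the digits printed from compound 3 to compound 4 (within the scatter), so a six-membered ring on this chain is accommodated as well as the open 2-methoxyethyl chain. Set against the simple ethyl group, the same ring gives a 1.8-fold higher number from compound 2 to compound 4 (0.24 log units; within the scatter), which means that all three groups compared at this position with the 2-(trifluoromethyl)phenyl group in place stay within the scatter of one another. With oxan-2-yl held constant, 2-(trifluoromethyl)phenyl in place of 2,3-dichlorophenyl on a saturated ring carbon gives a 2.9-fold lower number from compound 1 to compound 4 (0.46 log units; beyond the scatter), so the higher number of compound 1 goes with its aryl group and not with the oxan-2-yl, and this compound pair now shows that directly.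

No measurement shown here explains why this position responds so little to these changes. From the compounds shown here alone, it remains open whether an amine or a carboxylic acid on this chain, or a much longer chain, would stay equally close to these values.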